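The source may report more compounds than this note shows. Statements on the series, on what has been measured and on what is new or still open speak of the compounds shown alone.

Measured compounds:
Compound 1, `O=C(Nc1cccc(-n2cc(-c3ccncc3)c(-c3ccc(Cl)c(O)c3)n2)c1)Nc1cccc(C(F)(F)F)c1`, gives 1460 nM in a functional assay on NCI-H522 cells (Homo sapiens) for inhibition, read by sulforhodamine B assay, with a stated time of 48 h; a higher number here means a weaker inhibitor of growth, a lower number a stronger inhibitor of growth.
Compound 2, `COc1cc(-c2nn(-c3cccc(NC(=O)c4cccc(C(F)(F)F)c4)c3)cc2-c2ccncc2)ccc1Cl`, gives 1050 nM in this assay.
Compound 3, `COc1cc(-c2nn(-c3cccc(NC(=O)Nc4ccc(Cl)c(Cl)c4)c3)cc2-c2ccncc2)ccc1Cl`, gives 811 nM in this assay.

Compound 3 shows the lowest of these three numbers, yet its gaps to compound 2 and to compound 1 both lie within the scatter of repeated measurements, so no order among the three can be claimed. Among the compounds with values here, the only single-point step measured, a 1.3-fold lower number from compound 2 to compound 3 (0.11 log units; within the scatter), swaps the group on the carbonyl carbon and stays within the scatter.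

Compound 4, `O=C(Nc1cccc(-n2cc(-c3ccncc3)c(-c3ccc(Cl)c(O)c3)n2)c1)Nc1ccc(Cl)c(Cl)c1`, differs from compound 3 by hydrogen in place of methyl on an oxygen on an aromatic ring. Within the data shown here, no measured step changes this oxygen alone. Compound 1 also carries the hydroxy group, but it differs from compound 3 at the urea as well, and the values of compound 1 and compound 3 lie within the scatter of each other, which gives no sign that the hydroxy group moves the number.

The step of a 1.2-fold higher number from compound 3 to compound 4 (0.09 log units; within the scatter) is therefore expected to stay within the scatter, with no clear direction. Compound 4 is estimated to give about 1000 nM in this assay, within a range from 400 nM to 2500 nM.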

Compound 4, concentration for 50% growth inhibition: 1190 nM
The estimate for compound 4 lay 1.2-fold (0.08 log units) below the measured number; measured number inside the range.
By their numbers in this assay, from the lowest: compounds 3, 2, 4 and 1 (each within the scatter of the next).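

Within the data shown here, compound 4 gives the first direct reading of methoxy to hydroxy on the 4-chloro-3-methoxyphenyl group: in this assay there is a 1.5-fold higher number from compound 3 to compound 4 (0.17 log units; within the scatter) and so no shift that can be told from repeat-measurement noise. With the hydroxy group held in place, the urea end can also be compared on its own, and 3,4-dichlorophenyl in place of 3-(trifluoromethyl)phenyl gives a 1.2-fold lower number from compound 1 to compound 4 (0.09 log units; within the scatter) and is equally unresolved.

Going by these compounds, whether an ethoxy group on this oxygen, or an amine in place of the hydroxy group, would move the number stays open. Each of the four values lies within the scatter of the next, so neither place has yet shown a group that clearly changes the number in this assay. No measurement at hand bears on the reason for these results.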